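The source may hold more compounds than are shown below. What is called first, only, known or untested is meant among the compounds shown, and "the series" means these compounds.

Compound 3, `O=C(Nc1ccc(O)cc1)c1c(NO)cc(-c2ccccc2)oc1=O`, is known in an ADME assay on Huh-7 cells (Homo sapiens) for cytotoxicity, read by a luciferase reporter and WST assay, with a stated time of 3 days (a lower number here means that less compound is tolerated, a higher number that more compound is tolerated), only as a limit: compound 3 gives > 20000 nM. Compound 2, `O=C(Nc1ccc(Cl)cc1)c1c(NO)cc(-c2ccccc2)oc1=O`, likewise stands at a limit, and in this assay compound 2 gives > 20000 nM. Among the measured compounds shown here, the one compound with a number is compound 1, `COc1ccc(-c2cc(NO)c(C(=O)Nc3ccccc3)c(=O)o2)cc1`, which in this assay gives 16200 nM. The only measured step among these three, a step that the two limits leave unreadable from compound 2 to compound 3, is one that the two limits leave unreadable, so it shows neither a size nor a direction.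

The unmeasured compound 4 is `Cc1ccc(NC(=O)c2c(NO)cc(-c3ccccc3)oc2=O)cc1`. It differs from compound 3 in one place: methyl in place of hydroxy on an aromatic carbon. For the measured compounds named here, no measured step bears directly on this change; the step between compound 2 and compound 3 alters the same substituent but cannot be read, and compound 1 differs from compound 3 elsewhere. What the numbers do show is the limit of > 20000 nM in this assay, at which 2 of the 3 values shown sit, and nothing points away from it. Compound 4 is therefore expected to land in the same region, the expected step being a number no higher from compound 3 to compound 4 (the limit leaves the size open), nothing beyond the scatter. Compound 4 is estimated at 20000 nM in this assay, within 8000 nM to 40000 nM, with a fair chance that only a limit is reported.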

Compound 4, half-maximal cytotoxic concentration: > 20000 nM
Compound 4: no number, only a limit (the forecaster's own chance of this, stated with the estimate: 60%); the middle value sits exactly at the limit.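

In this assay compound 4 gives > 20000 nM, which is a limit and not a number. Compound 2 and compound 3 are also known only as limits, so no new step can be read between compound 4 and either of them. The compounds shown leave open whether methyl, hydroxy and chloro differ at all in this assay.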